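Butyl for cyclopentyl on sulfur: cytotoxicity notes

The source may hold more compounds than are shown below. What is called first, only, known or untested is meant among the compounds shown, and "the series" means these compounds.

Measured in an ADME assay on HFF cells (Homo sapiens) for cytotoxicity, with a stated time of 8 days; on this read-out higher numbers stand for lower toxicity in this test and lower numbers for higher toxicity in this test:
compound 1 `CNc1nc(N)nc2c1ncn2/C=C1/CC1(CO)CO`: 265000 nM
compound 2 `C=CCOc1nc(N)nc2c1ncn2/C=C1/CC1(CO)CO`: > 300000 nM
compound 3 `Nc1nc(SC2CCCC2)c2ncn(/C=C3/CC3(CO)CO)c2n1`: > 300000 nM

The values of compound 2 and compound 3 are limits, not numbers. Compound 3 stands at the limit of > 300000 nM in this assay, at which 2 of the 3 values shown sit.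

Compound 4 `CCCCSc1nc(N)nc2c1ncn2/C=C1/CC1(CO)CO` has butyl in place of cyclopentyl on a sulfur.

Within the data shown here, no measured step makes this exchange. The nearest steps change the whole group on the aromatic carbon. One is an at least 1.1-fold higher number from compound 1 to compound 3 (0.05 log units; that floor lies within the scatter), and the other is a step that the two limits leave unreadable from compound 2 to compound 3. Since neither shows a change beyond the scatter, no step beyond the scatter is expected in this assay.

The expected step is an at least 1.0-fold lower number from compound 3 to compound 4 (0.02 log units; that floor lies within the scatter).

Compound 4 is estimated at 280000 nM, with an expected range of 120000 nM to 300000 nM.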

Compound 4, half-maximal cytotoxic concentration: > 300000 nM
Compound 4: only a limit was reported (the forecaster's own chance of this, stated with the estimate: 70%); middle value at least 1.0-fold (0.02 log units) from the limit.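

With butyl on the sulfur in place of cyclopentyl, compound 4 also gives only a limit in this assay, so the open chain reaches the same ceiling as the ring: the limit of > 300000 nM in this assay, at which 3 of the 4 values shown sit. The steps from compound 2 and compound 3 to compound 4 have limits at both ends and cannot be read. Among these compounds, the one readable step is an at least 1.1-fold higher number from compound 1 to compound 4 (0.05 log units; that floor lies within the scatter), so butylsulfanyl in place of methylamino shows no change beyond the scatter.

On these data alone, how far the true values of compound 2, compound 3 and compound 4 lie past the limit stays open. Also open, as far as these compounds go, is whether a longer chain or a carboxylic acid on the sulfur would give a measurable number under the limit.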